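A few compounds are considered here, and "the series" means these few. Any claim that something is new, unique, unknown or untested is made for them only; others in the source may bear on it.

Working notes on the series in a functional assay on a cell-free system (plasma) with thromboxane A2 receptor (Homo sapiens) as the target; a lower number here means a stronger inhibitor, a higher number a weaker inhibitor.

Of the compounds shown here, three of the shared core have been measured. Compound 1 `CCCCCCSC[C@H]1C2CC[C@@H](O2)[C@H]1C/C=C\CCCC(=O)O` gives 83000 nM in this assay. Compound 2 `CCCCCSCCC1C2CCC(O2)C1C/C=C\CCCC(=O)O` gives 37000 nM. Compound 3 `O=C(O)CCC/C=C\CC1C2CCC(O2)C1CSCC1CCCCC1` gives 20000 nM, the lowest of the three numbers; the gap to compound 1 lies beyond the scatter, while the one listed step, a 1.9-fold lower number from compound 2 to compound 3 (0.27 log units; within the scatter), is within the scatter, so compound 3 and compound 2 are not separated by these data.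

The next compound, compound 4 `O=C(O)CCC/C=C\CC1C2CCC(O2)C1CSCCOc1ccccc1`, differs from compound 3 by phenoxymethyl in place of cyclohexyl on a saturated chain carbon bound to a sulfur.

Among the compounds with values here, no measured step exchanges a saturated ring for an aromatic ether on this side chain. The only step in the same region, a 1.9-fold lower number from compound 2 to compound 3 (0.27 log units; within the scatter), reshaped the sulfur-bearing chain and moved the number by less than the scatter; the comparison of compound 1 with compound 2 concerns a different part of that chain and is not a listed step. On this basis no change beyond the scatter is expected for compound 4, and the step of a 1.1-fold lower number from compound 3 to compound 4 (0.05 log units; within the scatter) is the estimated outcome.

Compound 4 is therefore expected to give about 18000 nM in this assay, with a plausible range from 5000 nM to 60000 nM.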

Compound 4, half-maximal inhibitory concentration: 20000 nM
For compound 4 the middle estimate is 1.1-fold (0.05 log units) below the measured one; low and high end bracket the measured number.
By their numbers in this assay, from the lowest: compounds 3, 4 and 2 (each within the scatter of the next); then compound 1.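

In this assay, phenoxymethyl in place of cyclohexyl on a saturated chain carbon bound to a sulfur gives no change at the digits printed from compound 3 to compound 4 (within the scatter), so a six-membered aromatic ring of carbon with an ether oxygen and a six-membered non-aromatic ring of carbon are not separated at this position by these data. Compound 4 is the only compound shown with an aromatic ring or an ether oxygen on this side chain, and the hydrogen-bond acceptor counted for phenoxymethyl comes with no change beyond the scatter, which the steps among the saturated side chains could not show. No measurement shown accounts for this result.

From the compounds shown here alone, whether an amine or a carboxylic acid on this side chain, or a longer chain in place of 2-phenoxyethyl, would move the number beyond the scatter remains open. Also open, going by these compounds, is whether chlorine or methoxy on the aromatic ring of phenoxymethyl would separate such a compound from compound 4.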